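Working notes: one stereocentre, drawn R or S

This account rests on a few compounds, and the source may have more. Where it says the series, first, only, none or still open, it means among the compounds named here.

For the measured compounds named here, the series so far holds two measured compounds, compound 1 `NCCCCN(C[C@@H]1Cc2ncccc2CN1)[C@H]1CCCc2cccnc21` and compound 2 `NCCCCN(C[C@H]1Cc2cccnc2CN1)[C@H]1CCCc2cccnc21`, and one compound still open, compound 3 `NCCCCN(C[C@@H]1Cc2cccnc2CN1)[C@H]1CCCc2cccnc21`. In an ADME assay for permeability, using PAMPA, with a stated time of 4 h, at pH 7.4 (on this read-out higher numbers stand for higher permeability and lower numbers for lower permeability), compound 1 gives 7 nm/s and compound 2 gives 6 nm/s. Going by the values given here, these two values lie within the scatter of each other, so compound 2 stands level with the only other number available.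

Compound 3 departs from compound 2 in one respect: the two compounds have the same atoms and bonds and differ only in configuration as drawn: 1 of 2 stereo elements differ; a stereocentre at a saturated ring carbon is drawn R in compound 2 and S in compound 3. Nothing leaves and nothing enters. The two compounds have the same atoms and bonds, and a stereocentre at a saturated ring carbon is drawn R in compound 2 and S in compound 3.

Among the compounds with values here, no measured pair isolates a change of this kind, so the data give no direct size for it. The anchor is compound 2 at 6 nm/s, and no step beyond the scatter is expected in this assay. The estimated change is no change at the digits printed from compound 2 to compound 3 (within the scatter), with no direction favoured. Compound 3 is expected at 6 nm/s, with an estimated range of 3 nm/s to 12 nm/s.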

Compound 3, apparent permeability: 77 nm/s
The estimate for compound 3 lay 13-fold (1.11 log units) below the measured number, and the stated range ends below it.
By their numbers in this assay, from the lowest: compounds 2 and 1 (each within the scatter of the next); then compound 3.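

In this assay the configuration at this saturated ring carbon is enough on its own to give a 13-fold higher number from compound 2 to compound 3 (1.11 log units; beyond the scatter), with nothing leaving and nothing entering. For the compounds shown here, the earlier compounds held no pair that isolated a change of this kind, so this is the first size the series gives for it, and it shows that the drawing of this one stereocentre cannot be treated as a detail when reading numbers on this read-out. The step can be assigned to configuration alone, because no other feature separates the pair: the fact that compounds 2 and 3 differ only in the configuration as drawn.

Going by these compounds, the other stereo element is drawn the same in compound 2 and compound 3, so what a change at that centre would do remains open, as does whether the configuration at the saturated ring carbon carries the same weight in the core of compound 1. Also open is whether a step of this size would persist with a carboxylic acid or a longer chain in place of the chain that ends in the amine, since every compound shown carries that same chain.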